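Phenyl for bromo on the thiophene core of compound 1

The source may hold more compounds than are shown below. What is called first, only, known or untested is meant among the compounds shown, and "the series" means these compounds.

Compound 1 `CC(C)(C)Cc1c(Br)sc(N)c1C(=O)c1cccc(Cl)c1` and compound 2 `Cc1ccc(C(=O)c2c(N)sc(Br)c2CC(C)(C)C)cc1` share a core and differ only in the aryl group on the carbonyl carbon. In an assay on CHO cells for displacement of a labelled ligand from adenosine receptor A3 (Homo sapiens), read by scintillation counting, tested at 10 uM (a lower number here means less inhibition, a higher number more inhibition at the concentration tested (going by the name of the read-out)), compound 1 gives 1%, and compound 2 gives 1%, so compound 1 stands level with compound 2 within the scatter. The measured step of no change at the digits printed from compound 1 to compound 2 (within the scatter) is the only one known, and it concerns the carbonyl-borne aryl group, not the ring carbon changed next.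

Compound 3 `CC(C)(C)Cc1c(-c2ccccc2)sc(N)c1C(=O)c1cccc(Cl)c1` is formed from compound 1 by the change (phenyl in place of bromo on an aromatic carbon). Among the measured compounds shown here, no measured step touches this position, so nothing here shows how a phenyl in place of bromo acts. For the measured compounds named here, the only guidance is that compound 1 and compound 2 both sit at the bottom of the scale. Compound 3 is therefore expected to stay near that level, a step of a number 4 percentage points higher from compound 1 to compound 3 (within the scatter) that is not expected to exceed the scatter, with an estimate of 5% ranging from -8% to 35%.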

Compound 3, a percentage reported as inhibition, at one concentration (the size of the read-out at that concentration, not a potency): 5%
The estimate for compound 3 equals the measured number at the digits printed, within the range that was stated.
By their numbers in this assay, from the lowest: compounds 1, 2 and 3 (each within the scatter of the next).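

In this assay, among the compounds shown here, the exchange of bromo for phenyl gives a number 4 percentage points higher from compound 1 to compound 3 (within the scatter) and thereby supplies the first reading at this ring carbon next to the ring sulfur, since the earlier step concerned only the aryl group on the carbonyl carbon. Compound 3 thus shows that a phenyl can stand at this position, in place of bromo, without the number leaving the low end of the scale on which compound 1 and compound 2 already sit. No measurement given here bears on the reason for this result.

On these data alone, what an amine, a carboxylic acid or a longer chain in place of bromo would do at this carbon remains open. Also open, as far as these compounds go, is whether phenyl at this position would read the same with the 4-methylphenyl of compound 2 on the carbonyl carbon.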